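From fluoro to methoxycarbonyl on a shared core

A few compounds are considered here, and "the series" means these few. Any claim that something is new, unique, unknown or untested is made for them only; others in the source may bear on it.

Compound 1 `Cc1cc(NC(=O)Nc2cccc([N+](=O)[O-])c2)c2ccccc2n1` and compound 2 `Cc1cc(NC(=O)Nc2cccc(F)c2)c2ccccc2n1` share a core and differ in a single group on an aromatic carbon. In an ADME assay on HEK293 cells (Homo sapiens) for cytotoxicity, with a stated time of 72 h (a lower number here means that less compound is needed, a higher number that more compound is needed for the effect), compound 1 gives > 25000 nM, which is a limit of the assay. Compound 2 gives > 25000 nM, and this too is a limit, not a number. All that is measured so far is the limit of > 25000 nM in this assay, at which 2 of the 2 values shown sit. Compound 3 `COC(=O)c1cccc(NC(=O)Nc2cc(C)nc3ccccc23)c1` carries methoxycarbonyl in place of fluoro on an aromatic carbon, meta to a large group: methoxycarbonyl in place of fluoro on an aromatic carbon. For the measured compounds named here, the one measured step, a step that the two limits leave unreadable from compound 1 to compound 2, offers no size to carry over, so no shift beyond the scatter is expected in this assay. The estimated change is a step that the limit leaves unreadable from compound 2 to compound 3. A reading at the limit is the likeliest outcome. For compound 3 the expected value is 30000 nM, with an estimated range from 12000 nM to 60000 nM.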

Compound 3, half-maximal effective concentration: 26000 nM
Estimate against measurement, compound 3: 1.2-fold (0.06 log units) above; low and high end bracket the measured number.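

Neither step to compound 3, from compound 1 or from compound 2, can be read in this assay, for the values of compound 1 and compound 2 are limits, not numbers. The compounds shown leave open how nitro, fluoro and methoxycarbonyl compare at this aromatic carbon.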